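The source may report more compounds than this note shows. Statements on the series, on what has been measured and on what is new or still open speak of the compounds shown alone.

Series notes. In a functional assay on SMMC-7721 cells (Homo sapiens) for inhibition, read by MTT assay, with a stated time of 72 h, tested at 1 uM (on this read-out higher numbers stand for a stronger effect at the one concentration tested and lower numbers for a weaker effect), compound 2 `Cc1cccc(COc2ccc(/C=C/C(/C=C/c3ccccn3)=N/Oc3ncnc4cccc(C)c34)cc2)c1` gives 93.4%, the highest of the three numbers. Compound 1 `Clc1ccc(COc2ccccc2/C=C/C(/C=C/c2ccccn2)=N/Oc2ncnc3cc(Cl)ccc23)c(Cl)c1` gives 23.6% and compound 3 `Clc1ccccc1COc1ccc(/C=C/C(/C=C/c2ccccn2)=N/Oc2ncnc3ccccc23)cc1` gives 10.1%; both gaps to compound 2 lie beyond the scatter. Within the data shown here, neither of these two compounds differs from compound 2 in a single place, so no step between measured compounds is known. Compound 4 `Cc1cccc(COc2ccc(/C=C/C(/C=C/c3ccccn3)=N/Oc3ncnc4cc(Cl)ccc34)cc2)c1` is the unmeasured analogue of compound 2: 7-chloroquinazolin-4-yl in place of 5-methylquinazolin-4-yl on an oxygen. Compound 1 also carries 7-chloroquinazolin-4-yl on the oxygen, though the rest of compound 1 differs from compound 2 as well. A drop beyond the scatter is expected for compound 4, the step of a number 48.4 percentage points lower from compound 2 to compound 4 (beyond the scatter) being estimated partly because compound 1 gives 23.6%. Compound 4 is therefore estimated at 45% in this assay, within 15% to 85%.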

Compound 4, a percentage reported as inhibition, at one concentration (the size of the read-out at that concentration, not a potency): 78.6%
Beside the measured number, compound 4's estimate is 33.6 percentage points below it; low and high end bracket the measured number.
By their numbers in this assay, from the lowest: compound 3; then compound 1; then compound 4; then compound 2.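

In this assay, among these compounds, 7-chloroquinazolin-4-yl in place of 5-methylquinazolin-4-yl on an oxygen gives a number 14.8 percentage points lower from compound 2 to compound 4 (beyond the scatter), the only step that isolates this place. The step is modest and compound 4 still gives 78.6%, so on this core 5-methylquinazolin-4-yl is not required for a high number at the one concentration tested. Nothing measured here accounts for the size of the step.

From the compounds shown here alone, whether this place also holds a high number with an amine or a longer alkyl chain on the quinazoline remains open. So does how the effects of the two compounds compare at other concentrations; a single concentration cannot show this.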